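Dropping the methoxy from a chromone dithiocarbamate

This account rests on a few compounds, and the source may have more. Where it says the series, first, only, none or still open, it means among the compounds named here.

In a functional assay on HEp-2 cells (Homo sapiens) for antiproliferative activity, read by MTT assay, with a stated time of 72 h (a lower number here means a stronger inhibitor, a higher number a weaker inhibitor), compound 1 `COc1ccc2oc(CSC(=S)N3CCOCC3)cc(=O)c2c1` gives 3000 nM, the lowest of the three numbers shown. Compound 2 `COc1ccc2oc(CSC(=S)N(C(C)C)C(C)C)cc(=O)c2c1` gives 7600 nM, and compound 3 `O=c1c(CSC(=S)N2CCN(C(c3ccc(F)cc3)c3ccc(F)cc3)CC2)coc2ccccc12` gives 9600 nM in this assay. For the measured compounds named here, the only single-point step measured, a 2.5-fold higher number from compound 1 to compound 2 (0.40 log units; beyond the scatter), concerns the amine on the thiocarbonyl carbon and not the aromatic ring. Going by the values given here, compound 4 `O=c1cc(CSC(=S)N2CCOCC2)oc2ccccc12` differs from compound 1 by hydrogen in place of methoxy on an aromatic carbon; no measured step covers this change, and compound 3, which also lacks the methoxy but carries a different amine and attachment, gives only an indirect hint that the unsubstituted core can be weaker. A modest step to a higher number is therefore expected for compound 4, a 1.7-fold higher number from compound 1 to compound 4 (0.22 log units; within the scatter), giving an estimated 5000 nM with a range from 2000 nM to 15000 nM.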

Compound 4, half-maximal inhibitory concentration: > 25000 nM
Compound 4: a limit, no number (the forecaster's own chance of this, stated with the estimate: 10%); middle value at least 5.0-fold (0.69 log units) from the limit.
By their numbers in this assay, from the lowest: compound 1; then compounds 2 and 3 (each within the scatter of the next). At a limit, above all of these: compound 4.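

With the morpholin-4-yl group held fixed, the methoxy proves to matter on this aromatic carbon: in this assay, hydrogen in its place gives an at least 8.3-fold higher number from compound 1 to compound 4 (0.92 log units; beyond the scatter). The earlier single-place step, a 2.5-fold higher number from compound 1 to compound 2 (0.40 log units; beyond the scatter), had spoken only for the amine. Compound 4 gives a limit and not a number: the limit of > 25000 nM in this assay, at which 1 of the 4 values shown sits.

From the compounds shown here alone, how large the full step is stays open. So does whether a hydroxyl, a chlorine or an ethoxy group on this carbon would hold the activity of compound 1, and whether losing the methoxy costs as much with the diisopropylamino group.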